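Two methyls along the acid chain of compound 1

This account rests on a few compounds, and the source may have more. Where it says the series, first, only, none or still open, it means among the compounds named here.

In an assay on membranes from lung (Cavia porcellus) for binding affinity to cysteinyl leukotriene receptor (Homo sapiens) (on this read-out lower numbers stand for stronger inhibition and higher numbers for weaker inhibition), the measured compounds are:
Compound 1, `O=C(O)CCCCc1cccc(OCc2ccc3ccccc3n2)c1`, 100 nM
Compound 2, `CCCC(CCC(=O)O)Cc1ccc(OCc2ccc3ccccc3n2)cc1`, 21 nM
Compound 3, `O=C(O)CCC(Cc1cccc(OCc2ccc3ccccc3n2)c1)c1ccccc1`, 52 nM

Compound 1 has the highest number of the three in this assay; compound 3 stands nearest to it and compound 2 furthest from it. Compound 4, `CC(Cc1cccc(OCc2ccc3ccccc3n2)c1)CC(C)C(=O)O`, has not yet been measured. It differs from compound 1 by 3-carboxy-1-methylbutyl in place of 3-carboxypropyl on a saturated chain carbon bound to an aromatic carbon. Among the compounds with values here, only one measured step changes a single place, and it bears on the present question only loosely: a 1.9-fold lower number from compound 1 to compound 3 (0.28 log units; within the scatter). That step puts a ring on the chain rather than two methyl groups, and it stays within the scatter. Compound 2 also carries a branched chain and gives a lower number than compound 1, but it differs from compound 1 in more than one place, so its value is no more than a hint. The step to compound 4 in this assay is therefore expected to be small, with any shift more likely toward a lower number than a higher one; the expected step is a 1.8-fold lower number from compound 1 to compound 4 (0.26 log units; within the scatter). Compound 4 is estimated at 55 nM, with a range from 20 nM to 150 nM.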

Compound 4, inhibition constant: 24 nM
Compound 4: middle estimate off by 2.3-fold (0.36 log units), on the high side, within the range that was stated.
By their numbers in this assay, from the lowest: compounds 2 and 4 (each within the scatter of the next); then compounds 3 and 1 (each within the scatter of the next).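

In this assay, within the data shown here, 3-carboxy-1-methylbutyl in place of 3-carboxypropyl on a saturated chain carbon bound to an aromatic carbon gives a 4.2-fold lower number from compound 1 to compound 4 (0.62 log units; beyond the scatter), so this chain responds to substitution by more than the scatter, which the only earlier single-place step, a 1.9-fold lower number from compound 1 to compound 3 (0.28 log units; within the scatter), did not show. The change needs no ring, since the entering group has none, and it leaves the counted hydrogen-bond donor, hydrogen-bond acceptor and net charge as they were, so a shift beyond the scatter here comes with added saturated carbons alone. Nothing measured in this account explains why the number falls.

Because the two methyl groups enter together, the compounds shown do not separate their contributions, and a single methyl on either carbon could account for all, part or none of the step. Nor do they show whether larger branches, such as an ethyl group, or a replacement of the carboxylic acid by a tetrazole would extend, keep or lose the shift, or whether the spatial arrangement of the two methyl groups matters.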